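Methoxy in Place of Fluoro: an Expected Limit

This account rests on a few compounds, and the source may have more. Where it says the series, first, only, none or still open, it means among the compounds named here.

Compound 3 `COc1cc(OC)c2c(=O)cc(/C=C/c3ccc(F)cc3)oc2c1` is one of three close relatives examined in a functional assay on PC-3 cells (Homo sapiens) for antiproliferative activity, read by MTT assay, with a stated time of 12 h; a higher number here means a weaker inhibitor, a lower number a stronger inhibitor. In this assay compound 3 gives only a limit, > 40000 nM, not a number. Compound 1 `COc1cc(OC)c2c(=O)cc(/C=C/c3ccccc3)oc2c1` likewise reaches only a limit in this assay, > 40000 nM. Compound 2 `COc1cc(OC)c2c(=O)cc(/C=C/c3ccc(Cl)cc3)oc2c1` also reaches only a limit in this assay, > 40000 nM. Because all three sit at the limit of > 40000 nM in this assay, at which 3 of the 3 values shown sit, the steps between them cannot be read: a step that the two limits leave unreadable from compound 1 to compound 2, a step that the two limits leave unreadable from compound 1 to compound 3 and a step that the two limits leave unreadable from compound 2 to compound 3 are each of unreadable size.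

Compound 4 `COc1ccc(/C=C/c2cc(=O)c3c(OC)cc(OC)cc3o2)cc1` differs from compound 3 by methoxy in place of fluoro on an aromatic carbon. Going by the values given here, none of the measured steps has a readable size, and so they set neither a direction nor a size for this change in this assay; the only pattern among the three measured compounds is that every one of them stays at the limit. Compound 4 is therefore expected to sit near 40000 nM in this assay, with a range from 10000 nM to 120000 nM, most likely again reported only as a limit. The step from compound 3 to compound 4 that this estimate means is expected to be a number no higher from compound 3 to compound 4 (the limit leaves the size open).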

Compound 4, half-maximal inhibitory concentration: > 40000 nM
Compound 4 ended at the assay's limit; the forecaster's own chance of this, stated with the estimate: 70%; the middle value sits exactly at the limit.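

In this assay, going by these compounds alone, compound 4 also gives only a limit, and its steps from compound 1, compound 2 and compound 3 cannot be read, so no new step emerges. All four compounds stand at the same place: the limit of > 40000 nM in this assay, at which 4 of the 4 values shown sit. The compounds shown leave open how hydrogen, chloro, fluoro and methoxy rank against one another in actual numbers.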